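Methoxy-to-hydrogen swap on the trimethoxyphenyl ketone side

This account rests on a few compounds, and the source may have more. Where it says the series, first, only, none or still open, it means among the compounds named here.

Three pyrazole-linked enones have been measured in a functional assay on MDA-MB-231 cells (Homo sapiens) for cytotoxicity, read by sulforhodamine B assay, with a stated time of 48 h, tested at 100 uM; a higher number here means a weaker effect of the compound at the concentration tested, a lower number a stronger effect. Compound 1 `COc1cc(-c2cc(/C=C/C(=O)c3ccc(N)cc3)[nH]n2)cc(OC)c1OC` gives -77%, and compound 2 `COc1ccc(-c2cc(/C=C/C(=O)c3ccc(N)cc3)[nH]n2)cc1OC` gives -77%; the step of no change at the digits printed from compound 1 to compound 2 (within the scatter), the change being (hydrogen in place of methoxy on an aromatic carbon). Compound 3 `COc1cc(C(=O)/C=C/c2cc(-c3cc(OC)c(OC)c(OC)c3)n[nH]2)cc(OC)c1OC` gives -96%, the strongest effect of the three, with the two others sitting beyond the scatter from it. How the core of compound 3 differs from that of compound 1 is not broken down here.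

Compound 4 `COc1ccc(-c2cc(/C=C/C(=O)c3cc(OC)c(OC)c(OC)c3)[nH]n2)cc1OC` is not yet measured. It carries the same change as that from compound 1 to compound 2: hydrogen in place of methoxy on an aromatic carbon. Since the earlier step of no change at the digits printed from compound 1 to compound 2 (within the scatter) stayed within the scatter, the step of a number 3 percentage points higher from compound 3 to compound 4 (within the scatter) is expected to be of similar size. Compound 4 is therefore estimated at -93%, within -100% to -78% in this assay.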

Compound 4, a percentage reported as activity, at one concentration (the size of the read-out at that concentration, not a potency): -71%
For compound 4 the middle estimate is 22 percentage points below the measured one; measured number outside the range, above it.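

Hydrogen in place of methoxy on an aromatic carbon does not carry over at one size between these two cores in this assay, where the new pair shows a number 25 percentage points higher from compound 3 to compound 4 (beyond the scatter) and the two steps differ: the same change on two cores in this assay, no change at the digits printed (within the scatter) from compound 1 to compound 2 and a number 25 percentage points higher (beyond the scatter) from compound 3 to compound 4, 25 percentage points apart, beyond the scatter of two such steps

A step read on one core therefore gives no safe estimate of the same change on the other core. Two pairs establish no rule for the series, and they do not show which structural difference between the cores accounts for the gap.

Open, as far as these compounds go, is how a hydroxy group, a fluorine atom or a longer alkoxy chain would read at the same aromatic carbon on either core. Also open, from the compounds shown here alone, is how the same change would read on further cores.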